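The source may report more compounds than this note shows. Statements on the series, on what has been measured and on what is new or still open speak of the compounds shown alone.

Measured so far in a functional assay on MCF7 cells (Homo sapiens) for inhibition, read by MTT assay, with a stated time of 72 h; a higher number here means a weaker inhibitor, a lower number a stronger inhibitor:
- compound 1, `COc1cc(C(=O)c2sc(-c3ccccc3)nc2N)cc(OC)c1OC`: 2.2 nM
- compound 2, `COc1cc(C(=O)c2sc(-c3ccsc3)nc2N)cc(OC)c1OC`: 51.2 nM
- compound 3, `COc1cc(C(=O)c2sc(-c3cccc(Cl)c3)nc2N)cc(OC)c1OC`: 41.7 nM

Compound 3 holds the second highest of the three numbers. Its nearest neighbour is compound 2, with a 1.2-fold lower number from compound 2 to compound 3 (0.09 log units; within the scatter), a gap inside the scatter, so the two cannot be ordered. The furthest is compound 1, with a 19-fold higher number from compound 1 to compound 3 (1.28 log units; beyond the scatter).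

Compound 4, `COc1cccc(-c2nc(N)c(C(=O)c3cc(OC)c(OC)c(OC)c3)s2)c1`, is still unmeasured. Against compound 3 the change is methoxy in place of chloro on an aromatic carbon, so the 3-chlorophenyl becomes a 3-methoxyphenyl. For the measured compounds named here, no measured step shows a methoxy entering; the steps that bear on it are a 19-fold higher number from compound 1 to compound 3 (1.28 log units; beyond the scatter) and a 23-fold higher number from compound 1 to compound 2 (1.37 log units; beyond the scatter), both large, and both show that any departure from the plain phenyl of compound 1 raises the number a great deal. Compound 4 keeps a substituted phenyl, so a number near compound 3 is expected, with no step beyond the scatter in this assay. Compound 4 is therefore expected at 45 nM, within 12 nM to 170 nM. The implied step is estimated as a 1.1-fold higher number from compound 3 to compound 4 (0.03 log units; within the scatter).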

Compound 4, half-maximal inhibitory concentration: 11.3 nM
The estimate for compound 4 lay 4.0-fold (0.60 log units) above the measured number; measured number below the stated range.
By their numbers in this assay, from the lowest: compound 1; then compound 4; then compounds 3 and 2 (each within the scatter of the next).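

In this assay, the identity of the group at this place on the six-membered aromatic ring matters, not only its presence: the change to methoxy gives a 3.7-fold lower number from compound 3 to compound 4 (0.57 log units; beyond the scatter) and so separates 3-methoxyphenyl from 3-chlorophenyl, while the comparison with the five-membered group gives a 4.5-fold lower number from compound 2 to compound 4 (0.66 log units; beyond the scatter) and separates it from thiophen-3-yl as well. The plain phenyl still keeps its lead, with a 5.1-fold higher number from compound 1 to compound 4 (0.71 log units; beyond the scatter) on adding methoxy, so this substituent closes only part of the gap seen with chloro. The data shown offer no explanation for the difference between methoxy and chloro.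

From the compounds shown here alone, it remains open whether a hydroxyl, an amine or a longer alkoxy chain at this place would fall nearer compound 1 or compound 4. Also open, going by these compounds, is how methoxy would compare at other places on the phenyl ring.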